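The compounds below may be only part of what the source reports. "The series", "measured", "known", "first", "only" and "open" are said of these compounds alone.

This account follows the step from compound 3 to compound 4 in an ADME assay on HEK293 cells (Homo sapiens) for cytotoxicity, read by CellTiter-Glo and resazurin assay, with a stated time of 72 h; on this read-out lower numbers stand for an effect already at smaller amounts and higher numbers for an effect only at larger amounts of compound. Of the compounds shown here, three have been measured so far. Compound 1 `CC(C)N(Cc1cccc(OCCCCCC(=O)O)c1)C(=O)c1ccc(-c2cccc(-c3ccccc3)c2)cc1` gives > 26000 nM in this assay, a limit of the measurement rather than a number. Compound 2 `CC(C)N(Cc1cccc(OCCCCCC(=O)O)c1)C(=O)c1ccc(-c2cc3ccccc3n2S(=O)(=O)c2ccccc2)cc1` likewise reaches only the limit > 26000 nM in this assay. Compound 3 `CCOC(=O)CCCCCOc1cccc(CN(C(=O)c2ccc(-c3cnc(OC)nc3OC)cc2)C(C)C)c1` also stands at the limit > 26000 nM in this assay, so no number is available for it. Where compound 3 stands is therefore only defined relative to the other two, and all three share the same outcome: the limit of > 26000 nM in this assay, at which 3 of the 3 values shown sit.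

Compound 4 `CCOC(=O)CCCCCOc1cccc(CN(C(=O)c2ccc(-c3cccc(C(F)(F)F)c3)cc2)C(C)C)c1` has not yet been measured in this assay. It differs from compound 3 in one place: 3-(trifluoromethyl)phenyl in place of 2,4-dimethoxypyrimidin-5-yl on an aromatic carbon. For the measured compounds named here, no measured pair in this set shows the effect of such a change, so no size of step can be read from the data. Given that compound 3 and the two other compounds all sit at the limit of this assay, the expectation is that compound 4 will again be reported at that limit, with no step beyond the scatter expected from compound 3 to compound 4 a number no higher from compound 3 to compound 4 (the limit leaves the size open). For compound 4 the estimated half-maximal effective concentration is 26000 nM, expected to lie between 13000 nM and 60000 nM, most probably as a limit.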

Compound 4, half-maximal effective concentration: > 26000 nM
Compound 4: no number, only a limit; the forecaster's own chance of this, stated with the estimate: 80%; the middle value sits exactly at the limit.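

In this assay compound 4 gives > 26000 nM, a limit and not a number. Compound 3 also stands only at a limit, so no step can be read from compound 3 to compound 4. The compounds shown leave open what their actual values are and which change, if any, would yield a measurable number: the limit of > 26000 nM in this assay, at which 4 of the 4 values shown sit.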